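This account rests on a few compounds, and the source may have more. Where it says the series, first, only, none or still open, it means among the compounds named here.

Measured compounds in a functional assay on MGC-803 cells (Homo sapiens) for antiproliferative activity, read by MTT assay, with a stated time of 48 h; on this read-out lower numbers stand for stronger inhibition and higher numbers for weaker inhibition:
compound 1, `O=C(Nc1cccc(CNc2nccnc2Cl)c1)Nc1ccccc1F`, gives 6440 nM
compound 2, `CCc1ccc(NC(=O)Nc2cccc(CNc3nccnc3Cl)c2)c(CC)c1`, gives 6130 nM
compound 3, `CC(C)(C)c1ccc(NC(=O)Nc2cccc(CNc3nccnc3Cl)c2)cc1`, gives 4820 nM

Compound 1 has the highest of the three numbers, but its nearest neighbour compound 2 and its furthest neighbour compound 3 both lie within the usual scatter of it, so the three measured compounds cannot be ranked against one another on these data. Among the measured compounds shown here, no step between two measured compounds differing in one place is available, so the effect of changing the aryl group on the urea has not been measured directly.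

Compound 4, `O=C(Nc1cccc(CNc2nccnc2Cl)c1)Nc1ccc(Cl)cc1Cl`, is the next compound in this assay. It differs from compound 1 as follows: 2,4-dichlorophenyl in place of 2-fluorophenyl on an amide-type nitrogen. The measured compounds give no direct guidance on this change, since the aryl variations seen so far (compound 2, compound 3) all stay within the scatter of compound 1. The expectation is therefore a step of a 1.4-fold lower number from compound 1 to compound 4 (0.16 log units; within the scatter), a small shift toward a lower number that may well remain within the scatter. Compound 4 is estimated at 4500 nM, with a range from 1800 nM to 11000 nM.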

Compound 4, half-maximal inhibitory concentration: 6430 nM
Compound 4: the middle estimate sits 1.4-fold (0.15 log units) below what was measured, and the stated range covers the measured number.
By their numbers in this assay, from the lowest: compounds 3, 2, 4 and 1 (each within the scatter of the next).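

In this assay, among the compounds shown here, the exchange of 2-fluorophenyl for 2,4-dichlorophenyl on the amide-type nitrogen gives a 1.0-fold lower number from compound 1 to compound 4 (0.00 log units; within the scatter) and provides the first direct one-place step at this position. On this read-out, the two halogen-bearing phenyl groups cannot be told apart, so this change at this position has no measurable effect on antiproliferative activity. No evidence is available that bears on why the two groups read alike.

On these data alone, whether a carboxylic acid or a dimethylamino group on this phenyl ring, or a straight alkyl chain in place of the ring, would shift the number beyond the scatter remains open. All the compounds shown keep the shared core, so the part played by that core in the read-out also stays open.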